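Halogen swap on the shared core: fluorine to bromine

The source may report more compounds than this note shows. Statements on the series, on what has been measured and on what is new or still open speak of the compounds shown alone.

Measured so far in an ADME assay on Huh-7 cells (Homo sapiens) for cytotoxicity, read by MTT assay, with a stated time of 4 h, at 37 degrees C; a lower number here means that less compound is tolerated, a higher number that more compound is tolerated:
- compound 1 `Cn1c(=O)c(-c2c(F)cccc2F)cc2c(N)nc(Nc3ccccc3)nc21` gives 10400 nM
- compound 2 `O=C1Nc2nc(Nc3ccccc3)nc(On3nnc4ccccc43)c2CC1c1ccc(Cl)cc1Cl` gives 5500 nM
- compound 3 `Nc1nc(Nc2ccccc2)nc2[nH]c(=O)c(-c3c(F)cccc3F)cc12` gives 2400 nM

Compound 3 shows the lowest number of the three, meaning the least compound is tolerated by the cells. For the measured compounds named here, compound 2 sits higher, and compound 1 higher still; the only step between single-change neighbours is a 4.3-fold lower number from compound 1 to compound 3 (0.64 log units; beyond the scatter), which concerns a hydrogen in place of methyl on an aromatic nitrogen.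

Compound 4 `Nc1nc(Nc2ccccc2)nc2[nH]c(=O)c(-c3c(Br)cccc3Br)cc12` is not yet measured. It differs from compound 3 in one place: 2,6-dibromophenyl in place of 2,6-difluorophenyl on an aromatic carbon. Going by the values given here, no measured step touches this position or this kind of change, so the step from compound 1 to compound 3 gives no direct guide. With nothing in the data pointing one way or the other, the expectation is a change no larger than the scatter, in either direction, so a 1.1-fold lower number from compound 3 to compound 4 (0.04 log units; within the scatter) is estimated as small. Compound 4 is therefore expected to give about 2200 nM in this assay, within a range from 800 nM to 6000 nM.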

Compound 4, half-maximal cytotoxic concentration: 166000 nM
Compound 4: the middle estimate sits 75-fold (1.88 log units) below what was measured, outside the stated range (above it).
By their numbers in this assay, from the lowest: compound 3; then compounds 2 and 1 (each within the scatter of the next); then compound 4.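

In this assay, for the compounds shown here, exchanging 2,6-difluorophenyl for 2,6-dibromophenyl on this aromatic carbon gives a 69-fold higher number from compound 3 to compound 4 (1.84 log units; beyond the scatter), so this position, which no earlier step touched, has a large bearing on how much compound the cells tolerate. The two groups have the same count of heavy atoms and neither has hydrogen-bond donors or acceptors, so these counts do not separate them and the visible difference lies in the halogen. No measurement shown here accounts for a step of this size.

The compounds shown leave open whether a 2,6-dichlorophenyl or 2,6-dimethylphenyl group would sit nearer compound 3 or compound 4, and whether one bromine would do the same as two. Also open, on these data alone, is whether this swap has a similar effect on the core of compound 1, with its methyl on the aromatic nitrogen.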